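This account rests on a few compounds, and the source may have more. Where it says the series, first, only, none or still open, it means among the compounds named here.

Compound 1 `C/N=C(\S)CCn1nc(-c2ccccc2)ccc1=O` is the reference point of this series. In a functional assay on the whole organism (stomach) for inhibition, with Rattus norvegicus as the target, at a dose of 100 mg/kg by the intraduodenal route (a higher number here means more inhibition at the dose given (going by the name of the read-out), a lower number less inhibition), compound 1 gives 68.2%, the highest of the three numbers at hand. Compound 3 `C/N=C(\S)CCn1ncccc1=O` gives 35.7% in this assay, and the step of a number 32.5 percentage points lower from compound 1 to compound 3 (beyond the scatter) goes with hydrogen in place of phenyl on an aromatic carbon. For the measured compounds named here, compound 2 `Cc1cc(=O)n(CCC(=N)S)nc1-c1ccccc1` gives 32% in this assay; no single-change step links it to compound 1, so the two values are simply noted as they stand.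

Compound 4 `C/N=C(/S)CCCCCn1nc(-c2ccccc2)ccc1=O` is not yet measured. It differs from compound 1 as follows: a group of 7 heavy atoms (5 carbon, 1 nitrogen, 1 sulfur; no ring) in place of a group of 4 heavy atoms (2 carbon, 1 nitrogen, 1 sulfur; no ring), on a saturated chain carbon, two bonds along the chain from an aromatic nitrogen. Going by the values given here, none of the measured steps alters this chain; the only measured step, a number 32.5 percentage points lower from compound 1 to compound 3 (beyond the scatter), concerns the phenyl and shows only that one change can move the read-out by a large amount here. For a longer chain no guide exists, so the expectation is a moderate loss with wide uncertainty. The estimated step is a number 13.2 percentage points lower from compound 1 to compound 4 (beyond the scatter). Compound 4 is therefore expected to give 55% in this assay, within a range from 30% to 78%.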

Compound 4, a percentage reported as inhibition, in the whole organism at one dose (the size of the read-out at that dose, not a potency): 92.3%
The estimate for compound 4 lay 37.3 percentage points below the measured number; the whole stated range lies below it.
By their numbers in this assay, from the lowest: compounds 2 and 3 (each within the scatter of the next); then compound 1; then compound 4.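

The chain on the saturated carbon is a position that responds in this assay, and the change reads as a number 24.1 percentage points higher from compound 1 to compound 4 (beyond the scatter), with a group of 7 heavy atoms in place of a group of 4 heavy atoms. The step on the phenyl lowered the read-out, whereas this change on the chain, with the phenyl kept, raises it, so the series can move upward as well as downward from compound 1. No measurement at hand accounts for this rise in inhibition.

For the compounds shown here, with only two chain lengths on the phenyl-bearing core, it remains open whether a chain of intermediate length or a still longer chain would follow the same direction. As far as these compounds go, it is also open whether the longer chain would raise the read-out without the phenyl, and how an amine or a carboxylic acid would fare in place of the sulfur-bearing end of the chain.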